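A few compounds are considered here, and "the series" means these few. Any claim that something is new, unique, unknown or untested is made for them only; others in the source may bear on it.

Measured so far:
compound 1, `CSC[C@H](NC(C)=O)C(=O)CCl` — 30300 nM
compound 2, `CCCCCSC[C@H](NC(C)=O)C(=O)CCl` — 5800 nM

In a functional assay on NALM-6 cells (Homo sapiens) (on this read-out higher numbers stand for weaker inhibition and lower numbers for stronger inhibition), compound 2 holds the lower of the two numbers shown; the only other measured compound, compound 1, lies above it by the step of a 5.2-fold lower number from compound 1 to compound 2 (0.72 log units; beyond the scatter), which came from butyl in place of hydrogen on a saturated chain carbon bound to a sulfur.

The compound now to be measured, compound 3, `CCCCCCCCCCSC[C@H](NC(C)=O)C(=O)CCl`, differs from compound 2 by pentyl in place of hydrogen on a saturated chain carbon, five bonds along the chain from a sulfur. This is the same kind of change as the measured step: the chain on the sulfur grows longer again. Among the compounds with values here, the one step that bears on it is a 5.2-fold lower number from compound 1 to compound 2 (0.72 log units; beyond the scatter), a modest lowering. Whether a second lengthening gives as much again is not shown by the two compounds measured, so a smaller step in the same direction seems the safer reading. Compound 3 is therefore expected to show a lowering of a 2.3-fold lower number from compound 2 to compound 3 (0.37 log units; beyond the scatter) in this assay. The estimate for compound 3 is 2500 nM, with a range from 800 nM to 8000 nM.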

Compound 3, half-maximal inhibitory concentration: 4700 nM
Estimate against measurement, compound 3: 1.9-fold (0.27 log units) below; the range from low to high includes it.
By their numbers in this assay, from the lowest: compounds 3 and 2 (each within the scatter of the next); then compound 1.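

In this assay, the second lengthening of the chain on the sulfur, pentyl in place of hydrogen on a saturated chain carbon, five bonds along the chain from a sulfur, gives a 1.2-fold lower number from compound 2 to compound 3 (0.09 log units; within the scatter) and so cannot be told apart from repeat-measurement noise. The first lengthening gave a 5.2-fold lower number from compound 1 to compound 2 (0.72 log units; beyond the scatter) and lay beyond that noise, so the two steps together show something a single step could not: adding carbons to this chain does not keep paying off at the same rate, and on these numbers compound 2 and compound 3 stand level. No measurement shown here explains why the earlier step counted and this one does not, so the flat result stands without a known cause.

Within the data shown here, what remains open is whether a still longer chain than the one in compound 3 would stay level or move the number in either direction, and whether a chain of intermediate length, such as one a carbon or two shorter, would behave any differently. Going by these compounds, it is equally open how a chain of similar length ending in an amine or a carboxylic acid would compare with these plain carbon chains.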